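From aminocyclohexyl to piperazine on the shared core

The source may report more compounds than this note shows. Statements on the series, on what has been measured and on what is new or still open speak of the compounds shown alone.

Measured so far in a functional assay on MCF7 cells (Homo sapiens) for cytotoxicity, read by fluorescence, with a stated time of 72 h; a lower number here means a stronger inhibitor, a higher number a weaker inhibitor
compound 1 `CC(C)c1n[nH]c2c(NCc3ccc(-c4ccccn4)cc3)nc(NCCO)nc12` gives 51 nM
compound 2 `CC(C)c1n[nH]c2c(NCc3ccc(-c4ccccn4)cc3)nc(N3CCCCC3CCO)nc12` gives 133 nM
compound 3 `CC(C)c1n[nH]c2c(NCc3ccc(-c4ccccn4)cc3)nc(N[C@@H]3CCCC[C@H]3N)nc12` gives 295 nM

Compound 3 has the highest number of the three, so at 295 nM it is the weakest inhibitor of this small set. Compound 4 `CC(C)c1n[nH]c2c(NCc3ccc(-c4ccccn4)cc3)nc(N3CCNCC3)nc12` has not yet been measured. It carries piperazin-1-yl in place of (2-aminocyclohexyl)amino on an aromatic carbon of the shared core.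

All three measured steps change this same place, and all are modest. They are a 2.6-fold higher number from compound 1 to compound 2 (0.42 log units; beyond the scatter) and a 2.2-fold higher number from compound 2 to compound 3 (0.35 log units; beyond the scatter) and, the largest of them, a 5.8-fold higher number from compound 1 to compound 3 (0.76 log units; beyond the scatter) across the set. Compound 2 is the closest guide, as its piperidin-1-yl group also puts a non-aromatic ring directly on that aromatic carbon, and it lies on the lower side of compound 3 (a 2.2-fold higher number from compound 2 to compound 3 (0.35 log units; beyond the scatter)). Going by the values given here, no measured compound carries piperazin-1-yl itself, so this comparison is only a loose one.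

A small move towards a lower number is therefore expected in this assay, with an estimated size of a 1.5-fold lower number from compound 3 to compound 4 (0.17 log units; within the scatter) at most modest. The estimate for compound 4 is 200 nM as a middle value, with an expected range from 70 nM up to 600 nM in this assay.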

Compound 4, half-maximal inhibitory concentration: 21 nM
Estimate against measurement, compound 4: 9.5-fold (0.98 log units) above; the measured number lies below the stated range.
By their numbers in this assay, from the lowest: compound 4; then compound 1; then compound 2; then compound 3.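

In this assay, going by these compounds alone, the earlier compounds left the open-chain (2-hydroxyethyl)amino group with the lowest number, yet piperazin-1-yl goes lower still (a 2.4-fold lower number from compound 1 to compound 4 (0.39 log units; beyond the scatter)), which makes compound 4 the strongest inhibitor of the four. Within the data shown here, a non-aromatic ring on this aromatic carbon is therefore no drawback in itself, and the choice of group matters far more than the earlier steps suggested: the change from 2-(2-hydroxyethyl)piperidin-1-yl gives a clear gain (a 6.3-fold lower number from compound 2 to compound 4 (0.80 log units; beyond the scatter)), and the change from (2-aminocyclohexyl)amino gives the largest step in the set (a 14-fold lower number from compound 3 to compound 4 (1.15 log units; beyond the scatter)). No measurement at hand offers a reason for these steps.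

The step from compound 3 to compound 4 changes several things at once, including the ring itself, the way it is attached and the loss of the defined stereocentres, so the compounds shown cannot separate their contributions. Morpholine, which has an oxygen in place of the second ring nitrogen, unsubstituted piperidine, which has a carbon there, and a methyl group on the free piperazine nitrogen would each test whether that nitrogen matters.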